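The compounds below may be only part of what the source reports. "The series", "measured", "known", "first", "only" and "open" are said of these compounds alone.

Three compounds share one core and differ only in the aryl group on the carbonyl carbon that sits on an amide-type nitrogen. In an assay on isolated protein for inhibition of Rho-associated protein kinase 2 (Homo sapiens), read by scintillation counting, radiometric assay and 33P incorporation, with a stated time of 40 min, in the presence of a further agent that is not named here (a higher number here means a weaker inhibitor, a lower number a stronger inhibitor), compound 1 `CC(C)(C)c1ccc(C(=O)Nc2cccc(NC(=O)COc3ccc4c(=O)ccoc4c3)c2)cc1` gives 34 nM, compound 2 `O=C(COc1ccc2c(=O)ccoc2c1)Nc1cccc(NC(=O)c2ccc(Br)cc2)c1` gives 49 nM, and compound 3 `COC(=O)c1ccc(C(=O)Nc2cccc(NC(=O)COc3ccc4c(=O)ccoc4c3)c2)cc1` gives 29 nM, the low end of the three numbers, though every step to it lies within the scatter: a 1.2-fold lower number from compound 1 to compound 3 (0.07 log units; within the scatter) and a 1.7-fold lower number from compound 2 to compound 3 (0.23 log units; within the scatter), as does a 1.4-fold higher number from compound 1 to compound 2 (0.16 log units; within the scatter). Compound 4 `O=C(COc1ccc2c(=O)ccoc2c1)Nc1cccc(NC(=O)c2cccc([N+](=O)[O-])c2)c1` carries 3-nitrophenyl in place of 4-(methoxycarbonyl)phenyl on a carbonyl carbon. All three measured steps, each an exchange of one substituent on this ring, bear on it, and none moved the number beyond the scatter, so no step beyond the scatter is expected in this assay, with a 1.4-fold higher number from compound 3 to compound 4 (0.14 log units; within the scatter). For compound 4 the estimate in this assay is 40 nM, with a range from 20 nM to 80 nM.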

Compound 4, half-maximal inhibitory concentration: 41 nM
The estimate for compound 4 lay 1.0-fold (0.01 log units) below the measured number; the measured number falls inside the stated range.
By their numbers in this assay, from the lowest: compounds 3, 1, 4 and 2 (each within the scatter of the next).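

In this assay, for the compounds shown here, the first aryl group with a 3-substituent rather than a 4-substituent stays within the scatter of all three earlier compounds (a 1.4-fold higher number from compound 3 to compound 4 (0.15 log units; within the scatter)), (a 1.2-fold lower number from compound 2 to compound 4 (0.08 log units; within the scatter)) and (a 1.2-fold higher number from compound 1 to compound 4 (0.08 log units; within the scatter)). The range of groups at this carbonyl carbon that leave the number unchanged within the scatter therefore now includes 3-nitrophenyl alongside the 4-substituted phenyl groups. No data here explain this flatness.

Open, on these data alone, is how 4-nitrophenyl would compare, which would separate the group from its place on the ring. Also open, as far as these compounds go, is whether a 4-aminophenyl or 4-carboxyphenyl group, or a cyclohexyl ring in place of the phenyl, would give a step beyond the scatter.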